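Swapping Amide for Methyl Ester on a Shared Core

This account rests on a few compounds, and the source may have more. Where it says the series, first, only, none or still open, it means among the compounds named here.

Measured so far:
compound 1 `COC(=O)c1ccc2c(ccn2-c2ccc(NC(=O)Nc3ccc(Cl)c(Cl)c3)cc2)n1`: 2800 nM
compound 2 `COC(=O)c1ccc2c(ccn2-c2ccc(NC(=O)Nc3ccc(Cl)c(C(F)(F)F)c3)cc2)n1`: 8200 nM
compound 3 `NC(=O)c1ccc2c(ccn2-c2ccc(NC(=O)Nc3cccc(Cl)c3Cl)cc2)n1`: 9800 nM

In an ADME assay on HS27 cells (Homo sapiens) for cytotoxicity, read by MTT assay (a lower number here means a stronger inhibitor, a higher number a weaker inhibitor), compound 3 gives the highest of the three numbers shown, though compound 2 lies within the scatter of it; only compound 1, with its lower number, sits beyond the scatter. Compound 4 `COC(=O)c1ccc2c(ccn2-c2ccc(NC(=O)Nc3cccc(Cl)c3Cl)cc2)n1` keeps the rest of compound 3 and differs in one place: methoxy in place of amino on a carbonyl carbon. Going by the values given here, the single measured step, a 2.9-fold higher number from compound 1 to compound 2 (0.47 log units; beyond the scatter), alters a different part of the molecule, so no measured step speaks to this exchange. The methoxycarbonyl is shared with compound 1 and compound 2, whose numbers span a modest range. With nothing to set a direction, the expected step of a 1.8-fold lower number from compound 3 to compound 4 (0.25 log units; within the scatter) is none beyond the scatter. Compound 4 is estimated at 5500 nM, within a range from 1800 nM to 17000 nM.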

Compound 4, half-maximal inhibitory concentration: > 10000 nM
Compound 4 gave a limit, no number; the forecaster's own chance of this, stated with the estimate: 10%; middle value at least 1.8-fold (0.25 log units) away from the limit.
By their numbers in this assay, from the lowest: compound 1; then compounds 2 and 3 (each within the scatter of the next). At a limit, above all of these: compound 4.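

In this assay compound 4 gave a limit and no number: (the limit of > 10000 nM in this assay, at which 1 of the 4 values shown sits). Methoxy in place of amino on the carbonyl carbon (an at least 1.0-fold higher number from compound 3 to compound 4 (0.00 log units; that floor lies within the scatter)) therefore cannot be read in either direction, and neither can the exchange of the aryl group measured against compound 2 (an at least 1.2-fold higher number from compound 2 to compound 4 (0.08 log units; that floor lies within the scatter)). Going by these compounds alone, with the methoxycarbonyl kept, 2,3-dichlorophenyl in place of 3,4-dichlorophenyl on the amide-type nitrogen gives the first readable step at this aryl position (an at least 3.5-fold higher number from compound 1 to compound 4 (0.55 log units; beyond the scatter)).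

Going by these compounds, how a carboxylic acid or an ethyl ester on the carbonyl carbon would read stays open. So does the true size of the carbamoyl to methoxycarbonyl step.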